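Chloro-to-fluoro exchange in benzothiazolyl thioureas and amines

The source may report more compounds than this note shows. Statements on the series, on what has been measured and on what is new or still open speak of the compounds shown alone.

Measured compounds:
- compound 1, `S=C(Nc1ccc(Cl)cc1)Nc1nc2ccccc2s1`: 39000 nM
- compound 2, `Fc1ccc(NC(=S)Nc2nc3ccccc3s2)cc1`: 26700 nM
- compound 3, `Fc1ccc2nc(Nc3nc4ccc(Cl)cc4s3)sc2c1`: 41000 nM

Of the compounds shown here, three have been tested in a functional assay on THP-1 cells (Homo sapiens) for cytotoxicity, read by MTT assay, with a stated time of 48 h; a higher number here means a weaker inhibitor, a lower number a stronger inhibitor. Compound 1 `S=C(Nc1ccc(Cl)cc1)Nc1nc2ccccc2s1` gives 39000 nM in this assay. Compound 2 `Fc1ccc(NC(=S)Nc2nc3ccccc3s2)cc1`, in which (fluoro in place of chloro on an aromatic carbon), gives 26700 nM. The step of a 1.5-fold lower number from compound 1 to compound 2 (0.16 log units; within the scatter) is small. Compound 3 `Fc1ccc2nc(Nc3nc4ccc(Cl)cc4s3)sc2c1` is built on a different core; the difference between the two cores is not broken down here. In this assay compound 3 gives 41000 nM, a number that lies within the scatter of both compound 1 and compound 2, so no order among the three can be claimed.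

Compound 4 `Fc1ccc2nc(Nc3nc4ccc(F)cc4s3)sc2c1` is not yet measured. Relative to compound 3, (fluoro in place of chloro on an aromatic carbon). Among the compounds with values here, this is the same kind of change as the one from compound 1 to compound 2, but the surroundings differ: in compound 2 the fluoro sits on a six-membered aromatic ring of carbon only, para to a large group, whereas in compound 4 it sits on a ring that is part of a fused system of two rings, meta and para to a fused ring.

Within the data shown here, the expectation for compound 4 rests on the single earlier example, compound 1 to compound 2, where the step of a 1.5-fold lower number from compound 1 to compound 2 (0.16 log units; within the scatter) stayed within the scatter. Compound 4 is therefore expected to show a step of about a 1.3-fold lower number from compound 3 to compound 4 (0.11 log units; within the scatter). In this assay compound 4 is estimated at 32000 nM, with a range from 15000 nM to 70000 nM.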

Compound 4, half-maximal inhibitory concentration: 17500 nM
Compound 4: middle estimate off by 1.8-fold (0.26 log units), on the high side; measured number inside the range.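

In this assay, fluoro in place of chloro on an aromatic carbon of the core of compound 3 gives a 2.3-fold lower number from compound 3 to compound 4 (0.37 log units; beyond the scatter), a modest step that lies beyond the scatter, whereas the earlier step with the same change stayed within it. Both steps run in the same direction, and the gap between them is too small to separate them: the same change on two cores in this assay, a 1.5-fold lower number (0.16 log units; within the scatter) from compound 1 to compound 2 and a 2.3-fold lower number (0.37 log units; beyond the scatter) from compound 3 to compound 4, 1.6-fold (0.21 log units) apart, within the scatter of two such steps. This shows that, across these two cores, the change lowered the number both times and that its size cannot be said to depend on the core, but it does not show that the step is truly larger on the core of compound 3, and two pairs are too few to make a rule for the series.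

The compounds shown leave open how a bromo, methyl or methoxy group in place of the chloro would compare on either core, and so whether the two steps reflect something particular to fluoro. They also leave open whether the same change would lower the number on a third core, such as one carrying an amide in place of the thiourea of compound 1.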